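Working notes: propyl in place of isopropyl

A few compounds are considered here, and "the series" means these few. Any claim that something is new, unique, unknown or untested is made for them only; others in the source may bear on it.

Compound 1 `CC(C)NCC(=O)NCC(=O)N(C)c1ccc(Cl)cc1C(=O)c1ccccc1Cl`: 1 mg/kg
Compound 2 `CC(=O)NCC(=O)N(C)c1ccc(Cl)cc1C(=O)c1ccccc1Cl`: 2.3 mg/kg
Compound 3 `CC(C)C(=O)NCC(=O)N(C)c1ccc(Cl)cc1C(=O)c1ccccc1Cl`: 6 mg/kg

All values come from a functional assay on the whole organism for antagonist activity, with Mus musculus as the target; a higher number here means that more compound is needed for the effect, a lower number that less compound is needed. Compound 3 has the highest number of the three, at 6 mg/kg. Compound 4 `CCCC(=O)NCC(=O)N(C)c1ccc(Cl)cc1C(=O)c1ccccc1Cl` carries propyl in place of isopropyl on a carbonyl carbon. The most relevant measured change is a 2.6-fold higher number from compound 2 to compound 3 (0.42 log units; beyond the scatter), with isopropyl in place of methyl on a carbonyl carbon. Among the measured compounds shown here, no measured step exchanges one propyl form for the other, so that modest step sets only a loose upper guide. The expected step is a 1.5-fold lower number from compound 3 to compound 4 (0.18 log units; within the scatter), towards a lower number and not beyond the scatter. For compound 4 the estimated value is 4 mg/kg, with an expected range of 1.8 mg/kg to 10 mg/kg.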

Compound 4, dose for half-maximal effect: 0.98 mg/kg
For compound 4 the middle estimate is 4.1-fold (0.61 log units) above the measured one, outside the stated range (below it).
By their numbers in this assay, from the lowest: compounds 4 and 1 (each within the scatter of the next); then compound 2; then compound 3.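

In this assay, rearranging the same carbons on the carbonyl carbon matters, as isopropyl to propyl gives a step beyond the scatter (a 6.1-fold lower number from compound 3 to compound 4 (0.79 log units; beyond the scatter)). Propyl in this series also improves on the shorter acyl end (a 2.3-fold lower number from compound 2 to compound 4 (0.37 log units; beyond the scatter)), so size alone does not set the order, with isopropyl going against any rise with chain size. The isopropylamino group is not required for this level of activity, since its replacement stays within the scatter (a 1.0-fold lower number from compound 1 to compound 4 (0.01 log units; within the scatter)).

Nothing available explains these steps. Going by these compounds, whether a longer chain such as butyl, a cyclopropyl ring or a carboxylic acid at this carbonyl carbon would hold the number of compound 4 remains open.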